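Lengthening the linker of a sulfonamide at the detection limit

The compounds below may be only part of what the source reports. "The series", "measured", "known", "first", "only" and "open" are said of these compounds alone.

Compound 3 `Cc1ccc(S(=O)(=O)NCCNc2nccc(-c3c(-c4cccc(F)c4)nc4sccn34)n2)cc1` belongs to a small set of analogues that share one core and differ in the side chain hanging from a nitrogen on an aromatic ring. In a functional assay on SK-MEL-28 cells (Homo sapiens) for cytotoxicity, read by MTT assay (on this read-out lower numbers stand for stronger inhibition and higher numbers for weaker inhibition), compound 3 gives only a limit, > 20000 nM. Compound 1 `O=S(=O)(NCCCNc1nccc(-c2c(-c3cccc(F)c3)nc3sccn23)n1)c1ccc(F)cc1` also returns only a limit in this assay, > 20000 nM. Within the data shown here, compound 2 `O=C(NCCNc1nccc(-c2c(-c3cccc(F)c3)nc3sccn23)n1)c1c(F)cccc1F` is the single member with a number, giving 11400 nM in this assay, and the step of an at least 1.7-fold higher number from compound 2 to compound 3 (0.24 log units; that floor lies within the scatter) shows how it relates to compound 3.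

Compound 4 `Cc1ccc(S(=O)(=O)NCCCNc2nccc(-c3c(-c4cccc(F)c4)nc4sccn34)n2)cc1` differs from compound 3 in one place: (((4-methylphenyl)sulfonyl)amino)methyl in place of ((4-methylphenyl)sulfonyl)amino on a saturated chain carbon, two bonds along the chain from a nitrogen on an aromatic ring. Among the measured compounds shown here, the step that the two limits leave unreadable from compound 1 to compound 3 is the only measured pair touching both chain lengths, and its size cannot be read because both values sit at the limit (the limit of > 20000 nM in this assay, at which 2 of the 3 values shown sit). Compound 1, which carries the longer chain, stays at the limit, so compound 4 is expected to remain there as well, a step that the limit leaves unreadable from compound 3 to compound 4 that means no change beyond the scatter. The estimate for compound 4 in this assay is therefore 30000 nM, with a range from 15000 nM to 100000 nM.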

Compound 4, half-maximal inhibitory concentration: 9500 nM
For compound 4 the middle estimate is 3.2-fold (0.50 log units) above the measured one; measured number outside the range, below it.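

In this assay, putting (((4-methylphenyl)sulfonyl)amino)methyl in place of ((4-methylphenyl)sulfonyl)amino on the saturated chain carbon gives an at least 2.1-fold lower number from compound 3 to compound 4 (0.32 log units; beyond the scatter), the first readable sign that chain length can matter for these sulfonamides. With the longer chain kept, methyl in place of fluoro on an aromatic carbon gives an at least 2.1-fold lower number from compound 1 to compound 4 (0.32 log units; beyond the scatter), and the change from the (2,6-difluorophenyl)carbonyl side chain of compound 2 gives a 1.2-fold lower number from compound 2 to compound 4 (0.08 log units; within the scatter). The two steps beyond the scatter give only minimum sizes, because each starts from a compound at a limit: the limit of > 20000 nM in this assay, at which 2 of the 4 values shown sit.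

As far as these compounds go, whether a longer chain would lower the number further remains open. So does what an amine or a carboxylic acid would do in place of the methyl on the aromatic ring.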